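The compounds below may be only part of what the source reports. "The series", "measured", "known", "first", "only" and "open" are said of these compounds alone.

Measured compounds, with the share of compound left after the set time:
Compound 1, `Cc1c(OCCCCOc2ccc(C(=O)O)cc2F)ccc(C(=O)CC2CCCC2)c1O`: 97%
Compound 2, `Cc1c(OCCCCOc2ccc(C(=O)O)cc2F)ccc(C(=O)CC(C)C)c1O`: 106%
Compound 3, `Cc1ccc(C(=O)O)cc1OCCCCOc1ccc(C(=O)CC2CCCC2)c(O)c1C`: 100%

In an ADME assay on a cell-free system (plasma, Rattus norvegicus) for metabolic stability, read by LC-MS, with a stated time of 60 min, tested at 100 uM (a higher number here means that more of the compound is left, a lower number that less of the compound is left), compound 2 gives the top number of the three, but compound 3 with 100% lies within the scatter of it, and so does compound 1, as the step of a number 9 percentage points higher from compound 1 to compound 2 (within the scatter) shows. Compound 4, `Cc1cc(OCCCCOc2ccc(C(=O)CC(C)C)c(O)c2C)ccc1C(=O)O`, differs from compound 2 in one place: 4-carboxy-3-methylphenyl in place of 4-carboxy-2-fluorophenyl on an oxygen on a saturated carbon. The measured step that bears on this is the swap at the same oxygen, a number 3 percentage points higher from compound 1 to compound 3 (within the scatter), which stayed within the scatter. A change at this end of the chain is therefore expected to leave the share of compound remaining essentially unchanged, a step of a number 4 percentage points lower from compound 2 to compound 4 (within the scatter). Compound 4 is estimated at 102%, with a range from 90% to 114%.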

Compound 4, percent of the compound remaining: 101%
For compound 4 the middle estimate is 1 percentage points above the measured one; measured number inside the range.
By their numbers in this assay, from the lowest: compounds 1, 3, 4 and 2 (each within the scatter of the next).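

In this assay the swap on this oxygen gives a number 5 percentage points lower from compound 2 to compound 4 (within the scatter) and so also leaves the share of compound remaining within the scatter when isopropyl, not cyclopentyl, sits on the chain at the other end. For the compounds shown here, the earlier swap at this oxygen was seen only with cyclopentyl, and with a different ring entering. No measurement here explains why these ring changes make so little difference.

As far as these compounds go, whether an amide in place of the carboxylic acid would behave the same stays open. So does the effect of a longer chain carrying this oxygen.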